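This account rests on a few compounds, and the source may have more. Where it says the series, first, only, none or still open, it means among the compounds named here.

Values in a functional assay on HCT-116 cells (Homo sapiens) for antiproliferative activity, read by MTT assay, with a stated time of 72 h (a higher number here means a weaker inhibitor, a lower number a stronger inhibitor), so far:
compound 1 `NC1=NC2(CCOCC2)N(OCCCOc2ccc(Cl)cc2)C(N)=N1` gives 690 nM
compound 2 `NC1=NC2(CCOCC2)N(OCCCOc2cccc(Cl)c2Cl)C(N)=N1` gives 5 nM
compound 3 `NC1=NC2(CCOCC2)N(OCCCOc2ccc(F)cc2)C(N)=N1` gives 3280 nM

Compound 3 has the highest number of the three, and its steps to both others lie beyond the scatter. The next structure is compound 4 `Cc1cc(C)cc(OCCCON2C(N)=NC(N)=NC23CCOCC3)c1` with 3,5-dimethylphenyl in place of 4-fluorophenyl on an oxygen on a saturated carbon is the whole difference.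

Changes at this place have already moved the number a long way. The step of a 660-fold higher number from compound 2 to compound 3 (2.82 log units; beyond the scatter) is large, as is a 140-fold lower number from compound 1 to compound 2 (2.14 log units; beyond the scatter) while a 4.8-fold higher number from compound 1 to compound 3 (0.68 log units; beyond the scatter) is modest. For the measured compounds named here, no measured compound carries methyl groups, so the guidance is indirect. Two substituents on the phenyl occur only in compound 2 at 5 nM and their placement there differs from that in compound 4. A large step toward a lower number is expected, stopping short of the value of compound 2.

In this assay the estimated step is a 22-fold lower number from compound 3 to compound 4 (1.34 log units; beyond the scatter) and it remains uncertain. For compound 4 a value of 150 nM is estimated, with 20 nM to 1000 nM as the expected range.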

Compound 4, half-maximal inhibitory concentration: 190 nM
Compound 4: middle estimate off by 1.3-fold (0.10 log units), on the low side, within the range that was stated.
By their numbers in this assay, from the lowest: compound 2; then compound 4; then compound 1; then compound 3.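

In this assay, 3,5-dimethylphenyl carries no halogen, yet it gives a lower number than both halogenated phenyl groups with a single substituent: a 17-fold lower number from compound 3 to compound 4 (1.24 log units; beyond the scatter) and a 3.6-fold lower number from compound 1 to compound 4 (0.56 log units; beyond the scatter). Halogen on the phenyl is therefore not required for a lower number among these four compounds, while two substituents alone do not reproduce the value of compound 2, as a 38-fold higher number from compound 2 to compound 4 (1.58 log units; beyond the scatter) shows. No measurement shown here accounts for these steps.

The 2,3-dichlorophenyl and 3,5-dimethylphenyl groups differ in both substituent identity and placement, so the contribution of each remains unresolved. From the compounds shown here alone, a 3,5-dichlorophenyl or 2,3-dimethylphenyl group would separate the two, and the effect of a longer chain to the phenyl ether also remains open.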